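Swapping a Phenyl Ring for Furan in Compound 4

The source may hold more compounds than are shown below. What is called first, only, known or untested is meant among the compounds shown, and "the series" means these compounds.

Compound 1 `COc1cc(/C=C/C(=O)/C=C/c2ccccc2)ccc1OCc1cn(CCCOc2cc(=O)oc3ccccc23)nn1`: 48%
Compound 2 `COc1ccc(/C=C/C(=O)/C=C/c2ccc(OCc3cn(CCCCCOc4cc(=O)oc5ccccc45)nn3)c(OC)c2)cc1`: 39%
Compound 3 `COc1ccc(/C=C/C(=O)/C=C/c2ccc(OCc3cn(CCOc4cc(=O)oc5ccccc45)nn3)c(OC)c2)cc1`: 78%

These three compounds were tested in a functional assay on THP-1 cells (Homo sapiens) for inhibition, read by sulforhodamine B assay, with a stated time of 48 h, tested at 50 uM; a higher number here means more inhibition of growth at the concentration tested, a lower number less inhibition of growth. Compound 1 gives 48%, and compound 2, with 39%, lies within the usual scatter of it, so the two cannot be told apart. Compound 3, at 78%, stands clearly higher than compound 1, beyond the scatter.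

Compound 4 `COc1cc(/C=C/C(=O)/C=C/c2ccco2)ccc1OCc1cn(CCCOc2cc(=O)oc3ccccc23)nn1` has not yet been measured. It differs from compound 1 in one place: furan-2-yl in place of phenyl on a double-bonded chain carbon bound to a double-bonded chain carbon. Among the measured compounds shown here, no measured pair here shows what this change does. The expectation is therefore a step from compound 1 to compound 4 of a number 3 percentage points lower from compound 1 to compound 4 (within the scatter), not beyond the scatter. Compound 4 is expected to give about 45%, between 25% and 68%.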

Compound 4, percent growth inhibition at one concentration: 57%
The estimate for compound 4 lay 12 percentage points below the measured number; the range from low to high includes it.
By their numbers in this assay, from the lowest: compounds 2, 1 and 4 (each within the scatter of the next, the first and the last beyond it); then compound 3.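

In this assay, among the compounds shown here, furan-2-yl in place of phenyl gives a number 9 percentage points higher from compound 1 to compound 4 (within the scatter), the first measured change at this position. This chain end therefore takes a five-membered aromatic ring with a hydrogen-bond acceptor without a shift that can be told from the scatter. Nothing measured here explains this result.

As far as these compounds go, whether thiophen-2-yl or pyridin-2-yl would fit as well remains open. So does whether the furan-2-yl swap would give a similar step on compound 3.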